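The compounds below may be only part of what the source reports. "The series", "measured", "known", "first", "only" and "open" are said of these compounds alone.

Measured compounds:
Compound 1 `O=S(=O)(Nc1ccc(-c2nc3ccccc3o2)cc1)c1cccc(Cl)c1`: in an assay on cells for inhibition of HSP60/HSP10 (Homo sapiens), with a stated time of 60 min (on this read-out lower numbers stand for stronger inhibition and higher numbers for weaker inhibition), compound 1 gives 54000 nM.
Compound 2 `O=S(=O)(Nc1ccc(-c2nc3ccccc3o2)cc1)c1cccc(C(F)(F)F)c1`: in this assay compound 2 gives 57000 nM.
Compound 3 `CCc1ccc(S(=O)(=O)Nc2ccc3oc(-c4ccccc4)nc3c2)cc1`: in this assay compound 3 reaches only a limit of the assay, > 100000 nM, not a number.

Compound 1 holds the lower of the two numbers shown, though both are weak, and compound 2 sits close to it, the move a 1.1-fold higher number from compound 1 to compound 2 (0.02 log units; within the scatter) being within the scatter. The third value shown is a limit (the limit of > 100000 nM in this assay, at which 1 of the 3 values shown sits).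

Compound 4 `CCc1ccc(S(=O)(=O)Nc2ccc(-c3nc4ccccc4o3)cc2)cc1` is built from compound 1 by one change: 4-ethylphenyl in place of 3-chlorophenyl on a sulfonyl sulfur. Within the data shown here, the only measured step that alters the group on the sulfonyl sulfur is the one from compound 1 to compound 2, and it produced no change beyond the scatter. Compound 3 carries the same 4-ethylphenyl group on a core that is joined differently, and it shows only a limit. Compound 4 is therefore expected to stay in the weak range, near compound 1 or somewhat higher; the estimate for compound 4 is 75000 nM, between 30000 nM and 200000 nM. The expected step is a 1.4-fold higher number from compound 1 to compound 4 (0.14 log units; within the scatter).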

Compound 4, half-maximal inhibitory concentration: > 100000 nM
Compound 4: a limit, no number (the forecaster's own chance of this, stated with the estimate: 35%); at least 1.3-fold (0.12 log units) between middle value and limit.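

Among these compounds, the earlier change on the sulfonyl sulfur stayed within the scatter, whereas 4-ethylphenyl in place of 3-chlorophenyl is the first change there to give a limit rather than a number in this assay, with an at least 1.8-fold higher number from compound 1 to compound 4 (0.26 log units; that floor lies within the scatter). Only the floor of this step is known, so the result does not establish a loss beyond the scatter, although the true gap may be larger. Compound 4 now shares a limit with compound 3, which carries the same 4-ethylphenyl group on a differently joined core: the limit of > 100000 nM in this assay, at which 2 of the 4 values shown sit.

The compounds shown do not separate the removal of chloro from the arrival of ethyl. They also leave open how an amine or a carboxylic acid on that phenyl ring, or a longer chain in place of ethyl, would read in this assay.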